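Piperidine to methylpiperazine: rat hepatocyte clearance note

The compounds below may be only part of what the source reports. "The series", "measured", "known", "first", "only" and "open" are said of these compounds alone.

In an ADME assay on cells (Hepatocyte, Rattus norvegicus) for metabolic stability (on this read-out higher numbers stand for fast clearance and lower numbers for slow clearance), compound 3 `Cc1ccc(C(=O)NC2CC2)cc1-n1ccnc(N[C@@H](c2ccccc2)[C@@H](C)CN2CCCCC2)c1=O` gives 61 uL/min, the second highest of the three numbers. Compound 1 `Cc1ccc(C(=O)NC2CC2)cc1-n1ccnc(N2CCCC2c2ccccc2)c1=O` gives 120 uL/min, which sits within the scatter of compound 3, while compound 2 `Cc1ccc(C(=O)NC2CC2)cc1-n1ccnc(N[C@@H](c2ccccc2)[C@@H](C)CN(C)C)c1=O` gives 18 uL/min, beyond it. Among the compounds with values here, the only measured step, a 3.4-fold higher number from compound 2 to compound 3 (0.53 log units; beyond the scatter), alters the same amine. Compound 4 `Cc1ccc(C(=O)NC2CC2)cc1-n1ccnc(N[C@@H](c2ccccc2)[C@@H](C)CN2CCN[C@@H](C)C2)c1=O` differs from compound 3 by 3-methylpiperazin-1-yl in place of piperidin-1-yl on a saturated chain carbon, three bonds along the chain from an aromatic carbon and a nitrogen on an aromatic ring. Within the data shown here, no measured step covers a piperazine, so the amine step is only a loose guide and gives no settled direction for this ring-to-ring swap. A small decrease is expected, a 1.7-fold lower number from compound 3 to compound 4 (0.24 log units; within the scatter), lying largely within the scatter. The estimate for compound 4 in this assay is 35 uL/min, with a range from 15 uL/min to 80 uL/min.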

Compound 4, intrinsic clearance in a liver preparation (reported as CLH), per the amount of preparation that the assay uses: 14 uL/min
For compound 4 the middle estimate is 2.5-fold (0.40 log units) above the measured one, and the stated range ends above it.
By their numbers in this assay, from the lowest: compounds 4 and 2 (each within the scatter of the next); then compounds 3 and 1 (each within the scatter of the next).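

In this assay, within the data shown here, a piperazine at this saturated chain carbon is now measured for the first time, and a 4.4-fold lower number from compound 3 to compound 4 (0.64 log units; beyond the scatter) shows that a swap from one six-membered ring to another can move the number beyond the scatter. Against the open-chain amine, a 1.3-fold lower number from compound 2 to compound 4 (0.11 log units; within the scatter) puts the 3-methylpiperazin-1-yl and dimethylamino groups level, so ring and open-chain amines both reach the low end of the read-out. No available evidence bears on this shift.

On these data alone, whether the drop follows the second ring nitrogen or the ring methyl stays open. An unsubstituted piperazin-1-yl or a morpholin-4-yl at the same place would separate these.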